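A few compounds are considered here, and "the series" means these few. Any claim that something is new, unique, unknown or untested is made for them only; others in the source may bear on it.

Working notes on the series. Three compounds have numbers in a functional assay on HCT-116 cells (Homo sapiens) for antiproliferative activity, read by MTT assay; a lower number here means a stronger inhibitor, a higher number a weaker inhibitor. Compound 1 `CCOC(=O)/C=N/c1cnc(Nc2ccc(N3CCN(C)CC3)cc2)nc1NC1CCCC1` gives 17000 nM in this assay. Compound 2 `NS(=O)(=O)c1ccc(Nc2ncc(/N=C/c3ccccc3)c(NC3CCCC3)n2)cc1` gives 26100 nM in this assay. Compound 3 `CCOC(=O)/C=N/c1cnc(Nc2ccc(N3CCN(C)CC3)cc2)nc1NC(C)C` gives 13600 nM in this assay, the lowest of the three numbers, with compound 1 nearest and compound 2 furthest, both gaps within the scatter. Going by the values given here, the only single-point step measured, a 1.3-fold lower number from compound 1 to compound 3 (0.10 log units; within the scatter), lies within the scatter.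

Compound 4 `CC(C)Nc1nc(Nc2ccc(N3CCN(C)CC3)cc2)ncc1/N=C/c1ccc(C(F)(F)F)cc1` is not yet measured. Relative to compound 3 the change is 4-(trifluoromethyl)phenyl in place of ethoxycarbonyl on a carbon with a double bond to nitrogen. Among the compounds with values here, no measured step covers this exchange on the imine carbon; the step from compound 1 to compound 3 concerns a different position and says nothing about it. Compound 2 does carry an aryl group on the same carbon, but it differs from compound 3 in two further places, so its value can only be placed beside that of compound 3, and the two lie within the scatter of each other. With nothing in hand that moves this assay beyond the scatter, the expected step of a 1.4-fold lower number from compound 3 to compound 4 (0.13 log units; within the scatter) is small and its direction uncertain. Compound 4 is estimated at 10000 nM in this assay, with a range from 2500 nM to 40000 nM.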

Compound 4, half-maximal inhibitory concentration: 42200 nM
Compound 4: the middle estimate sits 4.2-fold (0.63 log units) below what was measured; the whole stated range lies below it.
By their numbers in this assay, from the lowest: compounds 3, 1, 2 and 4 (each within the scatter of the next, the first and the last beyond it).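

In this assay, going by these compounds alone, the carbon with a double bond to nitrogen is the first place where a single change moves the number beyond the scatter: 4-(trifluoromethyl)phenyl in place of ethoxycarbonyl gives a 3.1-fold higher number from compound 3 to compound 4 (0.49 log units; beyond the scatter), whereas the only earlier step, a 1.3-fold lower number from compound 1 to compound 3 (0.10 log units; within the scatter), stayed within it. This exchange alters several things at once, including heavy-atom count, the presence of an aromatic ring and the number of hydrogen-bond acceptors, and one step cannot separate their contributions. Nothing available explains the rise in the number.

From the compounds shown here alone, it remains open whether the step belongs to the aromatic ring or to its trifluoromethyl group, and whether groups such as a carboxylic acid, a primary amide or a longer ester on this carbon would stay close to compound 3 at 13600 nM or depart from it. Going by these compounds, it is equally open whether the same exchange would give a step of similar size with cyclopentyl in place of isopropyl on the nitrogen on the aromatic ring.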